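This account rests on a few compounds, and the source may have more. Where it says the series, first, only, none or still open, it means among the compounds named here.

Measured compounds in a functional assay on MCF7 cells (Homo sapiens) for antiproliferative activity, read by sulforhodamine B assay, with a stated time of 48 h; a lower number here means a stronger inhibitor, a higher number a weaker inhibitor:

compound 1 `CC(C)c1ccccc1OS(=O)(=O)c1cccc(NC(=O)C(C)(C)C)c1` gives 14000 nM
compound 2 `CC(C)c1ccccc1OS(=O)(=O)c1cccc(NC(=O)CCl)c1` gives 2200 nM
compound 3 `CC(C)c1ccccc1OS(=O)(=O)c1ccc(NC(=O)C(C)(C)C)cc1` gives 6500 nM

Compound 1 and compound 3 share the same atoms joined differently; the difference between the two cores is not broken down here. Compound 3 stands second highest of the three measured numbers in this assay. From compound 1 to compound 2 the change is chloromethyl in place of tert-butyl on a carbonyl carbon, and the step is a 6.4-fold lower number from compound 1 to compound 2 (0.80 log units; beyond the scatter).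

Compound 4 `CC(C)c1ccccc1OS(=O)(=O)c1ccc(NC(=O)CCl)cc1` is not yet measured. It differs from compound 3 by chloromethyl in place of tert-butyl on a carbonyl carbon, which is the same change, at the same place, as that from compound 1 to compound 2. The expected step is a 6.5-fold lower number from compound 3 to compound 4 (0.81 log units; beyond the scatter), because a 6.4-fold lower number from compound 1 to compound 2 (0.80 log units; beyond the scatter) occurred with the identical change on the other core. This rests on a single measured pair, so the expectation is held loosely. Compound 4 is therefore estimated at 1000 nM, expected to fall between 400 nM and 3000 nM.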

Compound 4, half-maximal inhibitory concentration: 2900 nM
The estimate for compound 4 lay 2.9-fold (0.46 log units) below the measured number; measured number inside the range.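

Chloromethyl in place of tert-butyl on a carbonyl carbon again gives a lower number on the second core, with a 2.2-fold lower number from compound 3 to compound 4 (0.35 log units; beyond the scatter) in this assay on the core of compound 3. The direction of the change carries over from one core to the other, but its size does not: the same change on two cores in this assay, a 6.4-fold lower number (0.80 log units; beyond the scatter) from compound 1 to compound 2 and a 2.2-fold lower number (0.35 log units; beyond the scatter) from compound 3 to compound 4, 2.8-fold (0.45 log units) apart, beyond the scatter of two such steps

Two pairs give no rule for the size of the step on a further core, and they do not show what sets the gap between the steps.

As far as these compounds go, only tert-butyl and chloromethyl are compared here, so it remains open how a plain methyl, a bromomethyl or a longer chain on the same carbonyl carbon would behave on either core. From the compounds shown here alone, whether the lower numbers depend on the chlorine itself also remains open.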